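Swapping Methyl for Piperidin-1-yl on the Carbonyl

The source may report more compounds than this note shows. Statements on the series, on what has been measured and on what is new or still open speak of the compounds shown alone.

For the measured compounds named here, compound 2 `CC(=O)N1CCc2nc(C#Cc3ccccc3)sc2C1` is the only compound here with a measured number: in an assay on HEK293 cells for negative allosteric modulation of metabotropic glutamate receptor 5 (Homo sapiens), read by FLIPR, with a stated time of 1 h (a lower number here means a stronger inhibitor, a higher number a weaker inhibitor), compound 2 gives 90 nM. Compound 1 `O=C1NCCc2nc(C#Cc3cccc(F)c3)sc21` sits at the limit of > 10000 nM in this assay, at which 1 of the 2 values shown sits, so its > 10000 nM is a limit of this assay rather than a number. Compound 3 `O=C(N1CCCCC1)N1CCc2nc(C#Cc3ccccc3)sc2C1` differs from compound 2 by piperidin-1-yl in place of methyl on a carbonyl carbon, leaving the carbonyl and its ring nitrogen untouched. Going by the values given here, no measured step of this kind exists to lean on, so the expected change from compound 2 to compound 3, a 2.2-fold higher number from compound 2 to compound 3 (0.35 log units; beyond the scatter), is a modest weakening near the scatter. Compound 3 is estimated at 200 nM, likely between 50 nM and 1000 nM.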

Compound 3, half-maximal inhibitory concentration: > 10000 nM
Compound 3: no number, only a limit; the forecaster's own chance of this, stated with the estimate: 10%; middle value at least 50-fold (1.69 log units) away from the limit.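

On this carbonyl carbon, the change from methyl to piperidin-1-yl is far from tolerated: it brings an at least 110-fold higher number from compound 2 to compound 3 (2.04 log units; beyond the scatter). Activity at this position therefore depends strongly on the group carried there, and a small methyl cannot be freely exchanged for this larger ring. The value of compound 3 is a limit and not a number, so the full size of the step stays unknown: the limit of > 10000 nM in this assay, at which 2 of the 3 values shown sit.

From the compounds shown here alone, what remains open is where between these two groups activity is lost. Ethyl, cyclopropyl or dimethylamino on the same carbonyl carbon would show whether the ring, the nitrogen or the chain matters.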